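This account rests on a few compounds, and the source may have more. Where it says the series, first, only, none or still open, it means among the compounds named here.

Values in an ADME assay on microsomes from liver (Mus musculus) for metabolic stability, read by LC-MS, with a stated time of 30 min, tested at 1 ug/mL (on this read-out higher numbers stand for a more stable compound and lower numbers for a less stable compound), are these:
- compound 1 `CC(C)C(=O)N1CCC(C[C@@H](c2nc3ccc(F)cc3n2C2CC2)N2C(=O)CN(c3ccc(Oc4ccc(F)cc4)cc3)C2=O)CC1` gives 54%
- compound 2 `CC(C)C(=O)N1CCC(C[C@@H](c2nc3ccccc3n2C2CC2)N2C(=O)CN(c3ccc(Oc4ccc(F)cc4)cc3)C2=O)CC1` gives 29.4%
- compound 3 `COc1ccc(Oc2ccc(N3CC(=O)N([C@@H](CC4CCN(C(=O)C(C)C)CC4)c4nc5ccc(C)cc5n4C4CC4)C3=O)cc2)cc1` gives 22.8%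

Compound 3 lies within the scatter of compound 2 and beyond the scatter below compound 1. Compound 4 `COc1ccc(Oc2ccc(N3CC(=O)N([C@@H](CC4CCN(C(=O)C(C)C)CC4)c4nc5ccc(C)cc5n4C)C3=O)cc2)cc1` differs from compound 3 by methyl in place of cyclopropyl on an aromatic nitrogen and nothing else. Within the data shown here, no measured step touches that place. Among the measured compounds shown here, the only step available, a number 24.6 percentage points lower from compound 1 to compound 2 (beyond the scatter), puts hydrogen in place of fluoro on an aromatic carbon elsewhere, so it shows only that modest movement occurs. The expected step of a number 2.8 percentage points lower from compound 3 to compound 4 (within the scatter) in this assay therefore stays within the scatter. Compound 4 is estimated at 20% with an expected range from 8% to 36% in this estimate.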

Compound 4, percent of the compound remaining: 2.4%
Estimate against measurement, compound 4: 17.6 percentage points above, and the stated range ends above it.
By their numbers in this assay, from the lowest: compound 4; then compounds 3 and 2 (each within the scatter of the next); then compound 1.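

In this assay, among these compounds, the group on the aromatic nitrogen proves to matter: methyl in place of cyclopropyl gives a number 20.4 percentage points lower from compound 3 to compound 4 (beyond the scatter), the only measured step at this place. The earlier compounds shown here all carry cyclopropyl there, so they could not show this sensitivity. Nothing available explains the drop.

Going by these compounds, whether an ethyl group, a longer chain or an amine on that nitrogen would behave like methyl or like cyclopropyl remains open. So does whether the same step would appear with the fluoro group of compound 1 on the core.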